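This account rests on a few compounds, and the source may have more. Where it says the series, first, only, none or still open, it means among the compounds named here.

Measured so far:
Compound 1 `Cc1cc(Cc2cccc(Cl)c2)c(=O)n(CC(=O)Nc2ccc(Br)cc2)n1` gives in a functional assay on HL-60 cells (Homo sapiens), read by calcium flux (on this read-out higher numbers stand for an effect only at larger amounts of compound and lower numbers for an effect already at smaller amounts), the value > 50000 nM, which is a limit of the assay and not a number.
Compound 2 `Cc1cc(Cc2ccoc2)c(=O)n(CC(=O)Nc2ccc(Br)cc2)n1` gives in this assay the value > 50000 nM, again a limit of the assay.

Compound 1 therefore stands only at a limit: the two values shown both sit at the same boundary, as the evidence the limit of > 50000 nM in this assay, at which 2 of the 2 values shown sit, records. Within the data shown here, the single step among the measured compounds, a step that the two limits leave unreadable from compound 1 to compound 2, is unreadable for the same reason.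

Compound 3 `Cc1cc(Cc2cccc(Cl)c2)c(=O)n(CC(=O)Nc2ccc(I)cc2)n1` differs from compound 1 by iodo in place of bromo on an aromatic carbon. Among the measured compounds shown here, no measured step bears directly on this change, and the one step between the measured compounds is unreadable, so there is no basis to expect any size of movement in this assay in either direction. The estimate for compound 3 is 50000 nM, with a range from 10000 nM to 200000 nM, meaning an expected step of a number no higher from compound 1 to compound 3 (the limit leaves the size open), with a high chance that only a limit is reported.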

Compound 3, half-maximal effective concentration: > 50000 nM
Compound 3: no number, only a limit; the forecaster's own chance of this, stated with the estimate: 85%; the middle value lies on the limit itself.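

In this assay compound 3 gives > 50000 nM, a limit of the assay and not a number. The step between compound 1 and compound 3 therefore cannot be read: the limit of > 50000 nM in this assay, at which 3 of the 3 values shown sit.

The compounds shown leave open whether iodo in place of bromo, or any other change among them, alters the response at all.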